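A few compounds are considered here, and "the series" means these few. Any claim that something is new, unique, unknown or untested is made for them only; others in the source may bear on it.

Measured so far in a functional assay on HCT-116 cells (Homo sapiens) for cytotoxicity, read by MTT assay (on this read-out lower numbers stand for stronger inhibition and higher numbers for weaker inhibition), on the shared core:

- compound 1 `CCn1cc(C(=O)Nc2ccccc2)c(=O)c2cc(F)c(N3CCNC(C)C3)c(F)c21` gives 12700 nM
- compound 2 `CCn1cc(C(=O)Nc2ccccc2O)c(=O)c2cc(F)c(N3CCNC(C)C3)c(F)c21` gives 5370 nM
- compound 3 `CCn1cc(C(=O)Nc2cc([N+](=O)[O-])ccc2F)c(=O)c2cc(F)c(N3CCNC(C)C3)c(F)c21` gives 2600 nM

Compound 3 holds the lowest number of the three in this assay and is the reference for the next change. The next compound is compound 4 `CCn1cc(C(=O)Nc2nccs2)c(=O)c2cc(F)c(N3CCNC(C)C3)c(F)c21` with 1,3-thiazol-2-yl in place of 2-fluoro-5-nitrophenyl on an amide-type nitrogen, and the difference counts as 1,3-thiazol-2-yl in place of 2-fluoro-5-nitrophenyl on an amide-type nitrogen in full. The measured steps at this nitrogen are all modest, with a 2.4-fold lower number from compound 1 to compound 2 (0.37 log units; beyond the scatter) and a 4.9-fold lower number from compound 1 to compound 3 (0.69 log units; beyond the scatter) and a 2.1-fold lower number from compound 2 to compound 3 (0.32 log units; beyond the scatter) as the whole of the evidence. For the measured compounds named here, no measured compound carries a five-membered aromatic ring there, so the direction is uncertain. With the 2-fluoro-5-nitrophenyl of compound 3 gone, a modest move to a higher number is expected, no larger than a 4.9-fold lower number from compound 1 to compound 3 (0.69 log units; beyond the scatter) in size. The expected step is a 2.3-fold higher number from compound 3 to compound 4 (0.36 log units; beyond the scatter) as estimated here. For compound 4 the estimated value is 6000 nM with an expected range from 2000 nM up to 16000 nM in this assay's terms.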

Compound 4, half-maximal inhibitory concentration: 8660 nM
For compound 4 the middle estimate is 1.4-fold (0.16 log units) below the measured one, and the stated range covers the measured number.
By their numbers in this assay, from the lowest: compound 3; then compounds 2, 4 and 1 (each within the scatter of the next, the first and the last beyond it).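

In this assay, a five-membered aromatic ring with 2 hetero atoms now stands on the amide-type nitrogen, and 1,3-thiazol-2-yl does not hold the low number of the 2-fluoro-5-nitrophenyl group (a 3.3-fold higher number from compound 3 to compound 4 (0.52 log units; beyond the scatter)). Against the 2-hydroxyphenyl and phenyl groups, 1,3-thiazol-2-yl cannot be told apart (a 1.6-fold higher number from compound 2 to compound 4 (0.21 log units; within the scatter); a 1.5-fold lower number from compound 1 to compound 4 (0.17 log units; within the scatter)), so at this nitrogen, among the compounds shown, only the 2-fluoro-5-nitrophenyl group separates from it. No measurement at hand bears on why this exchange reads as it does.

It stays open whether the low number of compound 3 goes with the nitro group, the fluoro group or the pair; no compound shown carries one without the other. Also open, as far as these compounds go, is how a pyridinyl ring, or a phenyl bearing an amine or a carboxylic acid, would read on this nitrogen in this assay.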